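Changing the Substituent on the Ring Nitrogen

The source may report more compounds than this note shows. Statements on the series, on what has been measured and on what is new or still open speak of the compounds shown alone.

Compounds measured so far:
compound 1, `Oc1cc(C(F)(F)F)ccc1-c1nc(-c2ccccc2O)n(-c2ccc(Cl)cc2)n1`: 68%
compound 2, `Oc1cc(C(F)(F)F)ccc1-c1nc(-c2ccccc2O)n(-c2ccccc2C(F)(F)F)n1`: 71%

In a functional assay on PC-12 cells (Rattus norvegicus) for cytotoxicity, read by MTT assay, with stated times of 2 h and 24 h, tested at 1 uM (on this read-out lower numbers stand for a weaker effect and higher numbers for a stronger effect at the one concentration tested), compound 1 gives 68%, and compound 2 gives 71%. Compound 2 lies within the scatter of compound 1, so the two cannot be told apart: the step of a number 3 percentage points higher from compound 1 to compound 2 (within the scatter) is too small to count.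

Compound 3, `Oc1cc(C(F)(F)F)ccc1-c1nc(-c2ccccc2O)n(-c2cccc(F)c2)n1`, has not been measured. It differs from compound 2 by 3-fluorophenyl in place of 2-(trifluoromethyl)phenyl on an aromatic nitrogen. Within the data shown here, the only step that bears on this change is the one from compound 1 to compound 2, which also swapped the group on that aromatic nitrogen and stayed within the scatter. A similar outcome is therefore expected here, with a step of a number 3 percentage points lower from compound 2 to compound 3 (within the scatter) no larger than the scatter. Compound 3 is estimated at 68%, ranging from 55% to 80%.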

Compound 3, a percentage reported as activity, at one concentration (the size of the read-out at that concentration, not a potency): 67.2%
Compound 3: the middle estimate sits 0.8 percentage points above what was measured; the measured number falls inside the stated range.
By their numbers in this assay, from the lowest: compounds 3, 1 and 2 (each within the scatter of the next).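

Three phenyl groups on this aromatic nitrogen now cannot be told apart in this assay: the change to 3-fluorophenyl gives a number 3.8 percentage points lower from compound 2 to compound 3 (within the scatter) and a number 0.8 percentage points lower from compound 1 to compound 3 (within the scatter). This holds even though 3-fluorophenyl has fewer heavy atoms than 2-(trifluoromethyl)phenyl, so among these three compounds neither the size nor the placing of the substituent separates them on this read-out. Nothing available gives a reason for this sameness. As far as these compounds go, it remains open whether a phenyl ring carrying an amine or a carboxylic acid, or a longer alkyl chain in place of the ring, would stay equally close.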